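Methyl for chloro on the aryl ring: expected effect

The source may report more compounds than this note shows. Statements on the series, on what has been measured and on what is new or still open speak of the compounds shown alone.

Compound 1 `Cc1ccc2c(O)cc(-c3cccc(Cl)c3)nc2n1` gives > 100000 nM in a functional assay on PC-3 cells (Homo sapiens) for antiproliferative activity (on this read-out lower numbers stand for stronger inhibition of growth and higher numbers for weaker inhibition of growth), which is a limit of the assay and not a number (the limit of > 100000 nM in this assay, at which 1 of the 3 values shown sits).
Compound 2 `Cc1cccc(-c2cc(O)c3ccc(C)nc3n2)c1` gives 138 nM in this assay.
Compound 3 `Cc1cc(C)c2c(O)cc(-c3cccc(Cl)c3)nc2n1` gives 27.5 nM in this assay.

Compound 3 has the lowest number of the two measured values; compound 2 is the nearest, and that gap is beyond the scatter. The two cores differ as follows: methyl in place of hydrogen on an aromatic carbon, a step of an at least 3600-fold lower number from compound 1 to compound 3 (3.56 log units; beyond the scatter).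

Compound 4 `Cc1cccc(-c2cc(O)c3c(C)cc(C)nc3n2)c1` is not yet measured. It is related to compound 3 by the change (methyl in place of chloro on an aromatic carbon). The same change, (methyl in place of chloro on an aromatic carbon), has been made once before, giving a step of an at least 720-fold lower number from compound 1 to compound 2 (2.86 log units; beyond the scatter); the two places are described in the same words, so the change is the same. That earlier step starts from a limit, so its real size is not known.

For compound 4 a step of a 3.4-fold lower number from compound 3 to compound 4 (0.54 log units; beyond the scatter) in this assay is expected, resting on the direction of the earlier step and on compound 3 already standing at 27.5 nM. Compound 4 is therefore estimated at 8 nM, expected between 1.5 nM and 60 nM.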

Compound 4, concentration for 50% growth inhibition: 31600 nM
Compound 4: the middle estimate sits 4000-fold (3.60 log units) below what was measured; the measured number lies above the stated range.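

In this assay, methyl in place of chloro on an aromatic carbon does not carry from one core to the other: a 1100-fold higher number from compound 3 to compound 4 (3.06 log units; beyond the scatter) runs against the earlier step, and the two differ beyond the scatter: the same change on two cores in this assay, an at least 720-fold lower number (2.86 log units; beyond the scatter) from compound 1 to compound 2 and a 1100-fold higher number (3.06 log units; beyond the scatter) from compound 3 to compound 4, at least 830000-fold (5.92 log units) apart, beyond the scatter of two such steps
Methyl in place of hydrogen on an aromatic carbon behaves the same way, since a 230-fold higher number from compound 2 to compound 4 (2.36 log units; beyond the scatter) opposes the step made on the core of compound 1: the same change on two cores in this assay, an at least 3600-fold lower number (3.56 log units; beyond the scatter) from compound 1 to compound 3 and a 230-fold higher number (2.36 log units; beyond the scatter) from compound 2 to compound 4, at least 830000-fold (5.92 log units) apart, beyond the scatter of two such steps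
Compound 1 gives > 100000 nM, a limit of the assay and not a number, so the steps from it have a known direction but no known size, and the four compounds show that the two changes depend on each other without showing why.

On these data alone, with a single set of four compounds, it stays open whether compound 3 and compound 2 or compound 4 and compound 1 show the more general behaviour. Also open, as far as these compounds go, is how a fluoro or methoxy group on the same aromatic carbon would fare with and without the added methyl on the core.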